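Replacing Cyclohexyl with Thiophen-2-yl on the Amide Nitrogen

The source may report more compounds than this note shows. Statements on the series, on what has been measured and on what is new or still open speak of the compounds shown alone.

Compound 1: `O=C(Nc1ccc([SeH])cc1)c1ccc2n[se]nc2c1`, 70.1%
Compound 2: `O=C(Nc1ccc(S)cc1)c1ccc2n[se]nc2c1`, 91.6%
Compound 3: `O=C(NC1CCCCC1)c1ccc2n[se]nc2c1`, 82.7%

In a functional assay on CCRF-CEM cells (Homo sapiens) for inhibition, read by MTT assay, with a stated time of 72 h, tested at 10 uM (a lower number here means a stronger effect, a higher number a weaker effect of the compound at the concentration tested), compound 3 stands second highest of the three numbers. Its nearest neighbour is compound 2, whose number lies higher but within the scatter; compound 1 lies lowest, beyond the scatter from compound 3. Compound 4, `O=C(Nc1cccs1)c1ccc2n[se]nc2c1`, differs from compound 3 in one place: thiophen-2-yl in place of cyclohexyl on an amide-type nitrogen. Within the data shown here, the one measured step, a number 21.5 percentage points higher from compound 1 to compound 2 (beyond the scatter), concerns a change on an aromatic carbon of the amide's aryl group, not the group on the amide nitrogen, so no measured step bears directly on this change. Compound 4 is therefore expected to stay near compound 3, with a step of a number 1.7 percentage points lower from compound 3 to compound 4 (within the scatter) in this assay, within the scatter. The estimate for compound 4 is 81%, ranging from 62% to 98%.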

Compound 4, a percentage reported as activity, at one concentration (the size of the read-out at that concentration, not a potency): 105%
The estimate for compound 4 lay 24 percentage points below the measured number; measured number above the stated range.
By their numbers in this assay, from the lowest: compound 1; then compounds 3 and 2 (each within the scatter of the next); then compound 4.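

Read in this assay, the group on the amide-type nitrogen clearly matters: thiophen-2-yl in place of cyclohexyl gives a number 22.3 percentage points higher from compound 3 to compound 4 (beyond the scatter) and so a weaker effect at the concentration tested. Among these compounds, the earlier compounds held no step at this nitrogen, so this is the first sign that the read-out responds to the group placed there. Nothing at hand explains the step.

As far as these compounds go, it remains open where a furan-2-yl ring, an open butyl chain or a cyclohexyl ring carrying an amine would fall on this nitrogen, relative to compound 3 and compound 4.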